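Swapping the aryl group on the piperazine of a xanthine sulfonamide

This account rests on a few compounds, and the source may have more. Where it says the series, first, only, none or still open, it means among the compounds named here.

Compound 1 `CCCn1c(=O)[nH]c2nc(-c3ccc(S(=O)(=O)N4CCN(c5ccc(Br)cc5)CC4)cc3)[nH]c2c1=O` in an assay on CHO cells for displacement of a labelled ligand from adenosine receptor A3 (Homo sapiens), read by scintillation counting, with a stated time of 45 min, in the presence of a further agent that is not named here (on this read-out lower numbers stand for stronger inhibition and higher numbers for weaker inhibition), gives > 1000 nM, a limit of the assay.
Compound 2 `CCCn1c(=O)[nH]c2nc(-c3ccc(S(=O)(=O)N4CCN(c5cccc(Cl)c5)CC4)cc3)[nH]c2c1=O` in this assay gives 53.5 nM.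
Compound 3 `CCCn1c(=O)[nH]c2nc(-c3ccc(S(=O)(=O)N4CCN(c5cccc(Br)c5)CC4)cc3)[nH]c2c1=O` in this assay gives > 1000 nM, a limit of the assay.

Compound 3 thus sits at the limit of > 1000 nM in this assay, at which 2 of the 3 values shown sit, alongside compound 1. The step of an at least 18-fold higher number from compound 2 to compound 3 (1.27 log units; beyond the scatter) is large, while a step that the two limits leave unreadable from compound 1 to compound 3 cannot be read between two limits; an at least 18-fold lower number from compound 1 to compound 2 (1.27 log units; beyond the scatter) is also large. Compound 4 `CCCn1c(=O)[nH]c2nc(-c3ccc(S(=O)(=O)N4CCN(c5ccc(C)cc5)CC4)cc3)[nH]c2c1=O` differs from compound 3 by 4-methylphenyl in place of 3-bromophenyl on an amine nitrogen in a ring. Going by the values given here, no measured step joins a 4-methylphenyl to any of these, so the bromo-to-chloro step gives only a hint that the aryl group matters strongly. The number for compound 4 is expected to move an at least 2.5-fold lower number from compound 3 to compound 4 (0.39 log units; beyond the scatter), though it may again reach a limit. Compound 4 is estimated at 400 nM, between 50 nM and 3000 nM.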

Compound 4, inhibition constant: > 1000 nM
Compound 4 gave a limit, no number (the forecaster's own chance of this, stated with the estimate: 45%); middle value at least 2.5-fold (0.39 log units) from the limit.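

Moving to the 4-methylphenyl group gives an at least 18-fold higher number from compound 2 to compound 4 (1.27 log units; beyond the scatter), so the 3-chlorophenyl group of compound 2 remains the only aryl group here with a measured number. With a carbon-only substituent, too, this position yields no number in this assay: the limit of > 1000 nM in this assay, at which 3 of the 4 values shown sit. The steps joining compound 4 to compound 1 and to compound 3 run between two limits and cannot be read.

As far as these compounds go, how compound 1, compound 3 and compound 4 rank among themselves stays open. So does whether fluoro or methoxy in place of the chloro of compound 2 would give a measured number.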